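Notes on aromatic substitution in the compound 1 series

A few compounds are considered here, and "the series" means these few. Any claim that something is new, unique, unknown or untested is made for them only; others in the source may bear on it.

Measured in an assay on isolated protein for inhibition of high affinity nerve growth factor receptor (Homo sapiens), read by 33P incorporation; a higher number here means a weaker inhibitor, a lower number a stronger inhibitor:
- compound 1, `Nc1cccc(-c2cnc3[nH]cc(-c4ccncc4)c3c2)c1`: 42.7 nM
- compound 2, `CNc1cccc(-c2cnc3[nH]cc(-c4ccncc4)c3c2)c1`: 31.4 nM

Compound 1 gives the highest of the two numbers in this assay; its nearest neighbour is compound 2, and the step of a 1.4-fold lower number from compound 1 to compound 2 (0.13 log units; within the scatter) lies within the scatter, so the two compounds cannot be ordered on these data. Compound 3, `COc1ccc(-c2cnc3[nH]cc(-c4ccncc4)c3c2)cc1N`, has not been measured. Relative to compound 1 it carries methoxy in place of hydrogen on an aromatic carbon. For the measured compounds named here, the only measured step, a 1.4-fold lower number from compound 1 to compound 2 (0.13 log units; within the scatter), concerns methyl in place of hydrogen on a nitrogen on an aromatic ring and is within the scatter; no measured pair touches the aromatic carbon concerned, so there is no direct precedent for the new change. On that footing no step beyond the scatter is expected in this assay from compound 1 to compound 3, in either direction, but the range must stay wide. The expected step is a 1.1-fold higher number from compound 1 to compound 3 (0.02 log units; within the scatter). For compound 3 the estimate is 45 nM, with an expected range from 15 nM to 140 nM.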

Compound 3, half-maximal inhibitory concentration: 33.2 nM
Compound 3: the middle estimate sits 1.4-fold (0.13 log units) above what was measured, and the stated range covers the measured number.
By their numbers in this assay, from the lowest: compounds 2, 3 and 1 (each within the scatter of the next).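

In this assay, for the compounds shown here, methoxy in place of hydrogen on the aromatic carbon ortho to an amino group and para to a large group gives a 1.3-fold lower number from compound 1 to compound 3 (0.11 log units; within the scatter) and so gives the first reading at this carbon, where the addition of 2 heavy atoms produces no step beyond the scatter. The step of a 1.4-fold lower number from compound 1 to compound 2 (0.13 log units; within the scatter) on the amino nitrogen is also within the scatter, so neither of the two single changes made to compound 1 separates from it in this assay, whether on the nitrogen or on the aromatic carbon. No independent data bear on why the number stays within the scatter here.

From the compounds shown here alone, whether a longer chain such as propoxy, a halogen such as chlorine, or a carboxylic acid at this same carbon would move the number beyond the scatter remains open. Also open, going by these compounds, is whether methoxy at this carbon gives a similar result when the methylamino group of compound 2 replaces the amino group, and whether other carbons of the same ring respond in the same way.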